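The source may hold more compounds than are shown below. What is called first, only, known or untested is meant among the compounds shown, and "the series" means these compounds.

Compound 1 `CCCc1nc(-c2ccccc2)c(CNCCCN2CCN(c3cccc(F)c3)CC2)o1`: 3030 nM
Compound 2 `CCCc1nc(-c2ccccc2)c(CNCCN2CCN(c3ccc(F)cc3)CC2)o1`: 7080 nM
Compound 3 `CCCc1nc(-c2ccccc2)c(CNCCCN2CCN(c3cccc(Cl)c3)CC2)o1`: 1750 nM

All three were measured in an assay on HEK293 cells for inhibition of Voltage-dependent T-type calcium channel subunit alpha-1G (Homo sapiens), read by patch clamp; a higher number here means a weaker inhibitor, a lower number a stronger inhibitor. Compound 3 gives the lowest of the three numbers, but its distance from compound 1 is only a 1.7-fold lower number from compound 1 to compound 3 (0.24 log units; within the scatter), which lies within the usual scatter, so those two cannot be ranked against each other; compound 2 stands beyond the scatter from compound 3.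

Compound 4 `CCCc1nc(-c2ccccc2)c(CNCCCN2CCN(c3ccccc3F)CC2)o1` has not yet been measured. It differs from compound 3 in one place: 2-fluorophenyl in place of 3-chlorophenyl on an amine nitrogen in a ring. Among the compounds with values here, no measured step covers this exact change. Within the data shown here, the only single-site step among the measured compounds, from compound 1 to compound 3, is a 1.7-fold lower number from compound 1 to compound 3 (0.24 log units; within the scatter), a halogen swap that stays within the scatter. Among the measured compounds shown here, a change of where the halogen sits on that ring has no measured precedent here. The step in this assay is therefore expected to be small, a 1.7-fold higher number from compound 3 to compound 4 (0.23 log units; within the scatter), landing near the value of compound 1. Compound 4 is estimated at 3000 nM, with a likely range from 1200 nM to 8000 nM.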

Compound 4, half-maximal inhibitory concentration: 16100 nM
Compound 4: middle estimate off by 5.4-fold (0.73 log units), on the low side, and the stated range ends below it.
By their numbers in this assay, from the lowest: compounds 3 and 1 (each within the scatter of the next); then compound 2; then compound 4.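

The step of a 5.3-fold higher number from compound 1 to compound 4 (0.73 log units; beyond the scatter) in this assay changes only where the fluorine sits on the phenyl ring, and it lies beyond the scatter. The earlier swap of fluoro for chloro, a 1.7-fold lower number from compound 1 to compound 3 (0.24 log units; within the scatter), did not, so among these three compounds the halogen's place on the ring counts for more than which halogen it is. The step of a 9.2-fold higher number from compound 3 to compound 4 (0.96 log units; beyond the scatter) is also beyond the scatter, although it changes both the halogen and its place at once, so it cannot separate the two changes.

The compounds shown offer nothing that explains why the 2-fluorophenyl group gives the weaker inhibitor. They also leave open how a phenyl ring with no halogen, or one carrying a methoxy group, would behave on the same ring nitrogen.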